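A few compounds are considered here, and "the series" means these few. Any claim that something is new, unique, unknown or untested is made for them only; others in the source may bear on it.

Compound 1 `O=C(NC[C@H]1CN(c2ccc(-n3cccc3CN3CCC3)cc2)C(=O)O1)c1ccc(Cl)s1` gives 1520 nM in an assay on isolated protein (plasma) for inhibition of coagulation factor X (Oryctolagus cuniculus) (on this read-out lower numbers stand for stronger inhibition and higher numbers for weaker inhibition), the lowest of the three numbers measured. Compound 2 `O=C(NC[C@H]1CN(c2ccc(-n3cccc3CN3CCCCC3)cc2)C(=O)O1)c1ccc(Cl)s1` gives 3230 nM, and compound 3 `O=C(NC[C@H]1CN(c2ccc(-n3cccc3CN3CCCC3)cc2F)C(=O)O1)c1ccc(Cl)s1` gives 3010 nM. Within the data shown here, the one single-point step known is a 2.1-fold higher number from compound 1 to compound 2 (0.33 log units; beyond the scatter), a modest loss. Compound 4 `CCNCc1csc(-c2ccc(N3C[C@H](CNC(=O)c4ccc(Cl)s4)OC3=O)cc2)n1` differs from compound 1 by 4-((ethylamino)methyl)-1,3-thiazol-2-yl in place of 2-((azetidin-1-yl)methyl)-1H-pyrrol-1-yl on an aromatic carbon, on an aromatic carbon of a six-membered aromatic ring of carbon only. Among the measured compounds shown here, no measured step touches this kind of exchange, and compound 3 differs from compound 1 in two places, so its value says little here. For the measured compounds named here, the only evidence is that amine changes have moved this assay within about one modest step. Compound 4 is therefore expected to stay close to compound 1, with a 1.1-fold higher number from compound 1 to compound 4 (0.02 log units; within the scatter) as the estimated step, giving an expected 1600 nM with a range from 500 nM to 5000 nM.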

Compound 4, half-maximal inhibitory concentration: 1160 nM
For compound 4 the middle estimate is 1.4-fold (0.14 log units) above the measured one, within the range that was stated.
By their numbers in this assay, from the lowest: compounds 4, 1, 3 and 2 (each within the scatter of the next, the first and the last beyond it).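

At this place, on an aromatic carbon of a six-membered aromatic ring of carbon only, 4-((ethylamino)methyl)-1,3-thiazol-2-yl replaces 2-((azetidin-1-yl)methyl)-1H-pyrrol-1-yl with a 1.3-fold lower number from compound 1 to compound 4 (0.12 log units; within the scatter) in this assay. The earlier step changed only the saturated amine ring, whereas this one exchanges the five-membered aromatic ring and the amine together and stays within the scatter. No measurement shown explains this result. The compounds shown do not separate the effect of the 1,3-thiazol-2-yl ring from that of the ethylamino group. They also leave open how a carboxylic acid or a longer chain in place of that amine would read in this assay.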